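The source may hold more compounds than are shown below. What is called first, only, known or untested is meant among the compounds shown, and "the series" means these compounds.

Measured in a physicochemical assay for solubility, read by nephelometry, measured as kinetic solubility, with a stated time of 30 min; a lower number here means a less soluble compound, a higher number a more soluble compound:
- compound 1 `NCCOc1ccc([C@H]2CC[C@]3(CC2)OOC2(O3)C3CC4CC(C3)CC2C4)cc1`: > 100 ug/mL, a limit
- compound 2 `CC(C)(O)CNCCCOc1ccc([C@H]2CC[C@]3(CC2)OOC2(O3)C3CC4CC(C3)CC2C4)cc1`: > 100 ug/mL, a limit
- compound 3 `CC(C)(N)CCOc1ccc([C@H]2CC[C@]3(CC2)OOC2(O3)C3CC4CC(C3)CC2C4)cc1`: 50 ug/mL

Within the data shown here, compound 3 gives 50 ug/mL, the only true number in the set. The other two entries are limits, not numbers: the limit of > 100 ug/mL in this assay, at which 2 of the 3 values shown sit.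

The next compound, compound 4 `c1cc([C@H]2CC[C@]3(CC2)OOC2(O3)C3CC4CC(C3)CC2C4)ccc1OCCC1CCNCC1`, carries piperidin-4-yl in place of 1-amino-1-methylethyl on a saturated chain carbon, two bonds along the chain from an oxygen on an aromatic ring.

Two measured steps at this same place bear on the change: an at least 2.0-fold lower number from compound 1 to compound 3 (0.30 log units; that floor lies within the scatter), and an at least 2.0-fold lower number from compound 2 to compound 3 (0.30 log units; that floor lies within the scatter). Both are floors rather than sizes. The remaining step, a step that the two limits leave unreadable from compound 1 to compound 2, gives no size at all. None of the three brings piperidin-4-yl into the chain, so the guidance is indirect.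

With compound 3 at 50 ug/mL as the anchor, no change beyond the scatter is expected in this assay, and no firm direction can be read. The expected step, a 1.3-fold lower number from compound 3 to compound 4 (0.10 log units; within the scatter), is only a slight lean. For compound 4 the estimate is 40 ug/mL, with an expected range of 12 ug/mL to 100 ug/mL.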

Compound 4, solubility: > 100 ug/mL
Compound 4: no number, only a limit; the forecaster's own chance of this, stated with the estimate: 20%; middle value at least 2.5-fold (0.39 log units) away from the limit.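

In this assay compound 4 gives > 100 ug/mL, a limit and not a number. Among these compounds, the step reads an at least 2.0-fold higher number from compound 3 to compound 4 (0.30 log units; that floor lies within the scatter), so piperidin-4-yl, the one group in this set that brings a six-membered non-aromatic ring to the saturated chain carbon, two bonds along the chain from an oxygen on an aromatic ring, gives a reading that sits with the open-chain entries of compound 1 and compound 2 rather than with compound 3, though the step remains a floor and does not establish a real difference. The steps from compound 1 and compound 2 to compound 4 cannot be read, leaving compound 3 as the only entry with a true number and the ceiling of the read-out as the main limit on this series: the limit of > 100 ug/mL in this assay, at which 3 of the 4 values shown sit.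

As far as these compounds go, how far compound 4 lies past that limit remains open, so the order among compound 1, compound 2 and compound 4 cannot be told. Also open, from the compounds shown here alone, is whether a morpholin-4-yl group, a carboxylic acid or a longer chain at this place would give a number that can be read.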